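Aryl replacement at the chain end: compound 4 estimate

The source may report more compounds than this note shows. Statements on the series, on what has been measured and on what is new or still open speak of the compounds shown alone.

Measured so far in a physicochemical assay for lipophilicity, using the shake flask method, in phosphate buffer, measured as octanol-water partition, with a stated time of 5 h; a higher number here means a more lipophilic compound, a lower number a more polar compound:
compound 1 `O=C(CN1CCN(c2cc3c(cc2F)c(=O)c(C(=O)O)cn3C2CC2)CC1)Nc1ccc(C(=O)/C=C/c2ccccc2)cc1`: 1.29
compound 2 `COc1ccc(/C=C/C(=O)c2ccc(NC(=O)CN3CCN(c4cc5c(cc4F)c(=O)c(C(=O)O)cn5C4CC4)CC3)cc2)cc1`: 0.684
compound 3 `COc1cc(/C=C/C(=O)c2ccc(NC(=O)CN3CCN(c4cc5c(cc4F)c(=O)c(C(=O)O)cn5C4CC4)CC3)cc2)cc(OC)c1OC`: 0.753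

Compound 3 stands second highest of the three numbers; its nearest neighbour is compound 2 (a number 0.07 log units higher from compound 2 to compound 3 (within the scatter)), its furthest is compound 1 (a number 0.54 log units lower from compound 1 to compound 3 (beyond the scatter)).

Compound 4 `O=C(CN1CCN(c2cc3c(cc2F)c(=O)c(C(=O)O)cn3C2CC2)CC1)Nc1ccc(C(=O)/C=C/c2cccc([N+](=O)[O-])c2)cc1` has not been measured in this assay. Its difference from compound 3: 3-nitrophenyl in place of 3,4,5-trimethoxyphenyl on a double-bonded chain carbon bound to a double-bonded chain carbon.

Among the compounds with values here, the steps that bear on this change are those at the same place. The replacement of phenyl by 3,4,5-trimethoxyphenyl gave a number 0.54 log units lower from compound 1 to compound 3 (beyond the scatter), and methoxy in place of hydrogen gave a number 0.61 log units lower from compound 1 to compound 2 (beyond the scatter); the move from one methoxy-bearing ring to the other, a number 0.07 log units higher from compound 2 to compound 3 (within the scatter), did nothing beyond the scatter. Within the data shown here, no measured compound carries a nitro group, so the size of the present step can only be bracketed between the phenyl and trimethoxyphenyl values of compound 1 and compound 3. Compound 4 is expected to lie closer to compound 3 than to compound 1, with a step of a number 0.20 log units higher from compound 3 to compound 4 (within the scatter) that is expected to fall within or only just beyond the scatter, upward. The estimate for compound 4 in this assay is 0.95, in the range 0.55 to 1.4.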

Compound 4, partition coefficient: -0.0812
Beside the measured number, compound 4's estimate is 1.03 log units above it; measured number below the stated range.
By their numbers in this assay, from the lowest: compound 4; then compounds 2 and 3 (each within the scatter of the next); then compound 1.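

In this assay the place on a double-bonded chain carbon bound to a double-bonded chain carbon now separates one substituted ring from another: 3-nitrophenyl in place of 3,4,5-trimethoxyphenyl gives a number 0.83 log units lower from compound 3 to compound 4 (beyond the scatter) and 3-nitrophenyl in place of 4-methoxyphenyl gives a number 0.77 log units lower from compound 2 to compound 4 (beyond the scatter) while the two methoxy-bearing rings stayed within the scatter of each other. Nitro in place of hydrogen on an aromatic carbon gives a number 1.37 log units lower from compound 1 to compound 4 (beyond the scatter) against a number 0.61 log units lower from compound 1 to compound 2 (beyond the scatter) for methoxy in place of hydrogen, and the size of the step at this ring thus differs with the group that enters. All three substituted rings stand lower than the phenyl of compound 1, with none of the four compounds going against this, and compound 4 at -0.0812 is the only one of the four with a number under zero.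

A nitrile or an amine on the ring at this place would test whether the low number of compound 4 is particular to nitro, and nitro on another ring carbon would test how far it depends on where the group sits. Nothing measured here explains the size of these steps.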